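Gem-dimethyl on the glycinate arm of a styrylsulfonamide

A few compounds are considered here, and "the series" means these few. Any claim that something is new, unique, unknown or untested is made for them only; others in the source may bear on it.

The series shares a trimethoxystyryl sulfonamide core, varied at one position of the aniline ring. Compound 1 `COc1cc(OC)c(/C=C/S(=O)(=O)Nc2ccc(OC)c(O)c2)c(OC)c1` carries a hydroxy there and in a functional assay on K562 cells (Homo sapiens) for cytotoxicity, read by trypan blue exclusion, with a stated time of 96 h (a higher number here means a weaker inhibitor, a lower number a stronger inhibitor), compound 1 gives 15 nM. Compound 2 `COc1cc(OC)c(/C=C/S(=O)(=O)Nc2ccc(OC)c([N+](=O)[O-])c2)c(OC)c1` carries a nitro instead and gives 1000 nM; the step of a 67-fold higher number from compound 1 to compound 2 (1.82 log units; beyond the scatter). Compound 3 `COC(=O)CNc1cc(NS(=O)(=O)/C=C/c2c(OC)cc(OC)cc2OC)ccc1OC` carries a ((methoxycarbonyl)methyl)amino group and in this assay compound 3 gives 350 nM, the second highest of the three numbers; the step of a 23-fold higher number from compound 1 to compound 3 (1.37 log units; beyond the scatter), and the step of a 2.9-fold lower number from compound 2 to compound 3 (0.46 log units; beyond the scatter).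

Compound 4 `COC(=O)C(C)(C)Nc1cc(NS(=O)(=O)/C=C/c2c(OC)cc(OC)cc2OC)ccc1OC` differs from compound 3 by 1-(methoxycarbonyl)-1-methylethyl in place of (methoxycarbonyl)methyl on a nitrogen on an aromatic ring. Within the data shown here, none of the measured steps alters this arm; all three change the group attached to the aromatic ring itself, and two of them were large. The present change is remote from that position and adds only two methyls, so the step of a 1.1-fold higher number from compound 3 to compound 4 (0.06 log units; within the scatter) is expected to stay near the scatter. Compound 4 is estimated at 400 nM, within 150 nM to 1200 nM, because compound 3 sits at 350 nM.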

Compound 4, half-maximal inhibitory concentration: 300 nM
Compound 4: the middle estimate sits 1.3-fold (0.12 log units) above what was measured, and the stated range covers the measured number.
By their numbers in this assay, from the lowest: compound 1; then compounds 4 and 3 (each within the scatter of the next); then compound 2.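

In this assay the arm on the nitrogen accepts 1-(methoxycarbonyl)-1-methylethyl in place of (methoxycarbonyl)methyl with a 1.2-fold lower number from compound 3 to compound 4 (0.07 log units; within the scatter) as the whole effect, so at this position the larger group cannot be told apart from the smaller one. The branched arm also leaves the picture set by the group on the aromatic carbon intact, with a 3.3-fold lower number from compound 2 to compound 4 (0.52 log units; beyond the scatter) against the nitro compound and a 20-fold higher number from compound 1 to compound 4 (1.30 log units; beyond the scatter) against the hydroxy compound, so this branching recovers none of the gap to compound 1. Nothing measured here explains why the branched and unbranched arms read alike.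

From the compounds shown here alone, whether the carboxylic acid in place of the methyl ester would read differently remains open. So does whether a plain amine on the aromatic carbon, or a longer chain on the nitrogen, would come closer to compound 1.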